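This account rests on a few compounds, and the source may have more. Where it says the series, first, only, none or still open, it means among the compounds named here.

Compound 1 `CC(C)c1c(C(=O)N(C)Cc2ccccc2)nn(-c2ccc(F)cc2)c1OC[C@@H](O)C[C@@H](O)CC(=O)O` gives 5.2 nM in an assay on microsomes from liver for inhibition of 3-hydroxy-3-methylglutaryl-coenzyme A reductase (Rattus norvegicus) (on this read-out lower numbers stand for stronger inhibition and higher numbers for weaker inhibition), the lowest number of the three measured compounds. Compound 2 `CC(C)c1c(C(=O)NCC2CCCCC2)nn(-c2ccc(F)cc2)c1OC[C@@H](O)C[C@@H](O)CC(=O)O` gives 17 nM in this assay, and compound 3 `CC(C)c1c(C(=O)N2CCCC2c2ccccc2)nn(-c2ccc(F)cc2)c1OC[C@@H](O)C[C@@H](O)CC(=O)O` gives 14 nM. Compound 4 `CC(C)c1c(C(=O)NCc2ccccn2)nn(-c2ccc(F)cc2)c1OC[C@@H](O)C[C@@H](O)CC(=O)O` differs from compound 1 at a single point: ((pyridin-2-yl)methyl)amino in place of benzyl(methyl)amino on a carbonyl carbon. The measured steps that also replace the benzyl(methyl)amino group of compound 1 are a 3.3-fold higher number from compound 1 to compound 2 (0.51 log units; beyond the scatter) and a 2.7-fold higher number from compound 1 to compound 3 (0.43 log units; beyond the scatter), both modest rises beyond the scatter. Compound 4 likewise gives up the benzyl(methyl)amino group, so a comparable modest rise in this assay is expected, a 2.3-fold higher number from compound 1 to compound 4 (0.36 log units; beyond the scatter). Compound 4 is therefore estimated at 12 nM, with a range from 5 nM to 30 nM.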

Compound 4, half-maximal inhibitory concentration: 25 nM
The estimate for compound 4 lay 2.1-fold (0.32 log units) below the measured number; the range from low to high includes it.
By their numbers in this assay, from the lowest: compound 1; then compounds 3, 2 and 4 (each within the scatter of the next).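

A third, different replacement of benzyl(methyl)amino on the carbonyl carbon also weakens inhibition in this assay (a 4.8-fold higher number from compound 1 to compound 4 (0.68 log units; beyond the scatter)), so swapping in a ring with a nitrogen and adding an amide hydrogen does not restore the number of compound 1. Compound 4 stays within the scatter of the other two replacements (a 1.8-fold higher number from compound 3 to compound 4 (0.25 log units; within the scatter); a 1.5-fold higher number from compound 2 to compound 4 (0.17 log units; within the scatter)), so pyridin-2-yl in place of cyclohexyl makes no clear difference here. No measurement given here explains these steps.

On these data alone, the ring and the amide hydrogen change together from compound 1 to compound 4, so their separate contributions remain unknown. A plain benzylamino group, or a methyl on the amide nitrogen of compound 4, would separate them.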